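A Single Stereocentre Changed in a Growth Inhibition Series

The compounds below may be only part of what the source reports. "The series", "measured", "known", "first", "only" and "open" are said of these compounds alone.

- compound 1 (`Cc1cn([C@H]2C[C@H](CC3=CC(=O)C(=O)C=C3)[C@@H](CO[Si](C)(C)C(C)(C)C)O2)c(=O)[nH]c1=O`) no result reported
- compound 2 (`COc1ccc(C2([C@H]3C[C@H](n4cc(C)c(=O)[nH]c4=O)O[C@@H]3CO[Si](C)(C)C(C)(C)C)SCCCS2)cc1OC`) 3720 nM measured

Among the compounds with values here, in a functional assay on OVCAR-3 cells (Homo sapiens) for inhibition, read by sulforhodamine B assay, with a stated time of 48 h (on this read-out higher numbers stand for weaker inhibition of growth and lower numbers for stronger inhibition of growth), compound 2 gives 3720 nM as the only number available. For compound 1 no result was reported, so compound 2 cannot yet be ranked against any neighbour.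

Compound 3 (`COc1ccc(C2([C@H]3C[C@@H](n4cc(C)c(=O)[nH]c4=O)O[C@@H]3CO[Si](C)(C)C(C)(C)C)SCCCS2)cc1OC`) has not yet been measured. Its difference from compound 2 is small: the two compounds have the same atoms and bonds and differ only in configuration as drawn: 1 of 3 stereo elements differ; a stereocentre at a saturated ring carbon is drawn R in compound 2 and S in compound 3 and the two compounds have the same atoms and bonds. A stereocentre at a saturated ring carbon is drawn R in compound 2 and S in compound 3.

Within the data shown here, no measured pair shows how such an inversion plays out in this assay and the data offer no firm guide to direction. The expectation therefore starts from compound 2 at 3720 nM and allows no shift beyond the scatter, with only a slight lean toward weaker inhibition of growth. The estimate amounts to a 1.2-fold higher number from compound 2 to compound 3 (0.08 log units; within the scatter) in expected terms. Compound 3 is expected at 4500 nM with 1800 nM and 11000 nM as the estimated ends of its range.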

Compound 3, concentration for 50% growth inhibition: 11000 nM
The estimate for compound 3 lay 2.4-fold (0.39 log units) below the measured number; measured number inside the range.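

Inverting a stereocentre at a saturated ring carbon, from the R to the S drawing, gives in this assay a 3.0-fold higher number from compound 2 to compound 3 (0.47 log units; beyond the scatter), which means weaker inhibition of growth for the S drawing. Within the data shown here, this is the first pair with numbers on both sides, and it shows that this stereocentre registers on this read-out, since the configuration as drawn moves the number beyond the usual scatter. The step can be assigned to this one centre because nothing else separates the pair: the fact that compounds 2 and 3 differ only in the configuration as drawn

The compounds shown give only this one pair, at one stereocentre, and they say nothing about how the other two stereo elements bear on growth inhibition. As far as these compounds go, whether the R drawing would keep its advantage on this read-out if the shared core carried a different group, such as an amine or a carboxylic acid, also remains open.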